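The source may hold more compounds than are shown below. What is called first, only, known or untested is meant among the compounds shown, and "the series" means these compounds.

Compound 2 `CC(Sc1nc2c(cnn2C)c(=O)n1-c1ccccc1)c1cccc(O)c1` carries a 3-hydroxyphenyl group on a saturated chain carbon bound to a saturated chain carbon and a sulfur. Among the compounds with values here, in an assay on isolated protein for inhibition of Retinaldehyde dehydrogenase 3 (Homo sapiens) (on this read-out higher numbers stand for weaker inhibition and lower numbers for stronger inhibition), compound 2 gives 91 nM, the highest of the two numbers measured so far. Its closest neighbour is compound 1 `CC(Sc1nc2c(cnn2C)c(=O)n1-c1ccccc1)c1ccccn1`, which in this assay gives 89 nM, and the step of a 1.0-fold higher number from compound 1 to compound 2 (0.01 log units; within the scatter) shows that these two compounds cannot be told apart on this read-out.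

Compound 3 `CC(Sc1nc2c(cnn2C)c(=O)n1-c1ccccc1)c1cncnc1` has not yet been measured. It differs from compound 2 in one place: pyrimidin-5-yl in place of 3-hydroxyphenyl on a saturated chain carbon bound to a saturated chain carbon and a sulfur. Within the data shown here, the only measured step that bears on this change is the one from compound 1 to compound 2, where one ring on the same saturated chain carbon was exchanged for another and the number stayed within the scatter. Exchanging the ring a second time is therefore expected to leave the number about where it is, with at most a small rise in this assay for compound 3, an expected step of a 1.2-fold higher number from compound 2 to compound 3 (0.08 log units; within the scatter). The estimate for compound 3 is 110 nM, within a range of 40 nM to 320 nM.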

Compound 3, half-maximal inhibitory concentration: 100 nM
Compound 3: the middle estimate sits 1.1-fold (0.04 log units) above what was measured; the range from low to high includes it.
By their numbers in this assay, from the lowest: compounds 1, 2 and 3 (each within the scatter of the next).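

In this assay, the steps of a 1.1-fold higher number from compound 2 to compound 3 (0.04 log units; within the scatter) and a 1.1-fold higher number from compound 1 to compound 3 (0.05 log units; within the scatter) are both within the scatter, so pyridin-2-yl, 3-hydroxyphenyl and pyrimidin-5-yl cannot be told apart on the saturated chain carbon bound to a saturated chain carbon and a sulfur. This adds something that the first pair could not show: 3-hydroxyphenyl has 1 hydrogen-bond donor and a ring of carbon only, while pyrimidin-5-yl has 0 hydrogen-bond donors and a ring with 2 hetero atoms, yet this exchange leaves the read-out indistinguishable, so among these compounds the hydroxyl hydrogen is not required for the measured inhibition. No measurement available here explains why these three rings give indistinguishable numbers.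

On these data alone, all three compounds carry a six-membered aromatic ring at this place, so it remains open whether the numbers would hold with a group of another kind there, such as an amine, a carboxylic acid or a longer chain. The rest of the molecule is the same in all three, so these results also say nothing about how changes to the shared core would affect the read-out.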